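Sulfonyl aryl swap on the shared core: clearance outlook

The compounds below may be only part of what the source reports. "The series", "measured", "known", "first", "only" and "open" are said of these compounds alone.

Measured compounds:
- compound 1 `COc1ccc(-c2c(S(=O)(=O)c3cc(Cl)cc(Cl)c3)cnc3c(F)cccc23)cc1` — 2.11 mL/min
- compound 2 `O=S(=O)(c1cc(Cl)cc(Cl)c1)c1cnc2c(F)cccc2c1-c1ccccc1F` — 0.44 mL/min

In an ADME assay on microsomes from liver (Homo sapiens) for metabolic stability, tested at 2.5 uM (on this read-out lower numbers stand for slow clearance and higher numbers for fast clearance), compound 1 gives 2.11 mL/min, the higher of the two numbers; in this assay compound 2 gives 0.44 mL/min. For the measured compounds named here, the only measured step, a 4.8-fold lower number from compound 1 to compound 2 (0.68 log units; beyond the scatter), concerns the aryl on the core carbon, not the sulfonyl aryl, so it does not bear on the change to compound 3 `COc1ccc(-c2c(S(=O)(=O)c3cccc(F)c3)cnc3c(F)cccc23)cc1`. Compound 3 differs from compound 1 as follows: 3-fluorophenyl in place of 3,5-dichlorophenyl on a sulfonyl sulfur. Going by the values given here, no measured pair shows this exchange, and the data give no basis for a direction. The expected step for compound 3 is a 1.5-fold lower number from compound 1 to compound 3 (0.18 log units; within the scatter), with a wide range, and a step of no more than the scatter would not be surprising. The estimate for compound 3 in this assay is 1.4 mL/min, within 0.5 mL/min to 3.5 mL/min.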

Compound 3, intrinsic clearance in a liver preparation (reported as CLH), per the amount of preparation that the assay uses: 2.48 mL/min
Compound 3: middle estimate off by 1.8-fold (0.25 log units), on the low side, within the range that was stated.
By their numbers in this assay, from the lowest: compound 2; then compounds 1 and 3 (each within the scatter of the next).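

In this assay, for the compounds shown here, the first measured change at the sulfonyl sulfur gives a 1.2-fold higher number from compound 1 to compound 3 (0.07 log units; within the scatter), so 3-fluorophenyl in place of 3,5-dichlorophenyl leaves the read-out within the scatter. Going by these compounds alone, on the core of compound 1, carrying 4-methoxyphenyl, this position therefore tolerates the exchange of the two chlorine atoms for one fluorine atom without a readable change in clearance, whereas the only step beyond the scatter so far remains the one on the aromatic carbon. No supporting data bear on why the exchange leaves the number within the scatter.

Still open, on these data alone, is whether the same exchange stays within the scatter with 2-fluorophenyl on the aromatic carbon, as in compound 2. Also open, as far as these compounds go, is how clearance responds to a sulfonyl aryl carrying an amine or a carboxylic acid.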